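A few compounds are considered here, and "the series" means these few. Any claim that something is new, unique, unknown or untested is made for them only; others in the source may bear on it.

Measured so far:
compound 1, `ClCc1cccc(Cn2cnc3ncnc(Cl)c32)c1`, 7070 nM
compound 2, `ClCc1ccc(Cn2cnc3nc(Cl)nc(Cl)c32)cc1`, 1860 nM
compound 3, `ClCc1cccc(Cn2cnc3nc(Cl)nc(Cl)c32)c1`, 1440 nM

All three were tested in a functional assay on SN12C cells (Homo sapiens) for cytotoxicity, read by sulforhodamine B assay, with a stated time of 48 h; on this read-out higher numbers stand for weaker inhibition of growth and lower numbers for stronger inhibition of growth. Compound 3 and compound 2 share the same atoms joined differently; the difference between the two cores is not broken down here, and their two values lie within the scatter of each other. Compound 1 and compound 3 differ by one change, (hydrogen in place of chloro on an aromatic carbon), and that step is a 4.9-fold higher number from compound 3 to compound 1 (0.69 log units; beyond the scatter).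

Compound 4, `ClCc1ccc(Cn2cnc3ncnc(Cl)c32)cc1`, has not yet been measured. It differs from compound 2 by hydrogen in place of chloro on an aromatic carbon, the same change as from compound 3 to compound 1; among the compounds shown this change occurs in both of these pairs and in no other.

The expectation for compound 4 rests on one example: because the step of a 4.9-fold higher number from compound 3 to compound 1 (0.69 log units; beyond the scatter) went toward weaker growth inhibition, a step of similar size is expected from compound 2 to compound 4, namely a 4.6-fold higher number from compound 2 to compound 4 (0.66 log units; beyond the scatter). Compound 4 is therefore estimated at 8500 nM, expected to fall between 3500 nM and 20000 nM.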

Compound 4, concentration for 50% growth inhibition: 3630 nM
For compound 4 the middle estimate is 2.3-fold (0.37 log units) above the measured one, within the range that was stated.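

In this assay the same replacement of chloro by hydrogen on an aromatic carbon gives a 2.0-fold higher number from compound 2 to compound 4 (0.29 log units; within the scatter), so on this core the effect of the change cannot be told apart from the scatter of repeated measurements, whereas on the core of compound 3 it stood beyond that scatter. The data therefore give no sign that the change behaves differently on the two cores, but they do not show that it has a fixed size, and two pairs cannot show how it would behave on any further core in this series. The two steps can be set side by side as follows: the same change on two cores in this assay, a 4.9-fold higher number (0.69 log units; beyond the scatter) from compound 3 to compound 1 and a 2.0-fold higher number (0.29 log units; within the scatter) from compound 2 to compound 4, 2.5-fold (0.40 log units) apart, within the scatter of two such steps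

The compounds shown leave open what an amine, a methoxy group or a longer chain would do in place of the chloro group that lies between two ring nitrogen atoms. They also leave open whether an amine or a hydroxyl group could take the place of the other chloro group on that ring, which compound 1 and compound 4 both keep.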